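Swapping a Lactam for an Indole on the Shared Core

The source may hold more compounds than are shown below. What is called first, only, known or untested is meant among the compounds shown, and "the series" means these compounds.

For the measured compounds named here, compound 2 `Cc1cc(N2CCCC2=O)c2ncc(CSCCc3ccccc3)n2c1` is the only compound with a number in an ADME assay on HEL cells (Homo sapiens) for cytotoxicity, with a stated time of 3 days (a lower number here means that less compound is tolerated, a higher number that more compound is tolerated), where compound 2 gives 25 ug/mL. Compound 1 `Cc1cc(N2CCCC2)c2ncc(CSCCc3ccccc3)n2c1` reaches only a limit in this assay, > 100 ug/mL, and that is the limit of > 100 ug/mL in this assay, at which 1 of the 2 values shown sits, rather than a number. Going by the values given here, the one measured step, an at least 4.0-fold lower number from compound 1 to compound 2 (0.60 log units; beyond the scatter), shows that exchanging the pyrrolidin-1-yl for a 2-oxopyrrolidin-1-yl made the compound less well tolerated. Compound 3 `Cc1cc(-n2ccc3ccccc32)c2ncc(CSCCc3ccccc3)n2c1` is not yet measured; it differs from compound 2 by 1H-indol-1-yl in place of 2-oxopyrrolidin-1-yl on an aromatic carbon. The measured step concerns a different exchange at the same position, so it only loosely bears on this one, and the data give no ground for a direction. The step from compound 2 to compound 3 is therefore expected to be small, about a 1.7-fold lower number from compound 2 to compound 3 (0.22 log units; within the scatter). Compound 3 is estimated at 15 ug/mL, within a range from 4 ug/mL to 60 ug/mL.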

Compound 3, half-maximal cytotoxic concentration: > 100 ug/mL
Compound 3: only a limit was reported; the forecaster's own chance of this, stated with the estimate: 15%; middle value at least 6.6-fold (0.82 log units) from the limit.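

At this position on the shared core, more heavy atoms in the group do not go with a lower number: in this assay there is an at least 4.0-fold higher number from compound 2 to compound 3 (0.60 log units; beyond the scatter) when 1H-indol-1-yl replaces 2-oxopyrrolidin-1-yl. Among the three groups tried here, only 2-oxopyrrolidin-1-yl gives a measured number, while the other two compounds stop at a limit of the assay: the limit of > 100 ug/mL in this assay, at which 2 of the 3 values shown sit. Because compound 1 and compound 3 both sit at that limit, the step between them cannot be read.

The compounds shown leave open whether the lower number follows the carbonyl itself or the 2-oxopyrrolidin-1-yl group as a whole. They also leave open how a morpholine ring, an open-chain amide or a simple phenyl ring would behave at this position.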